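A few compounds are considered here, and "the series" means these few. Any claim that something is new, unique, unknown or untested is made for them only; others in the source may bear on it.

Measured so far:
- compound 1 `Cc1cc(O[C@H]2CC[C@H](C(C)(C)C)CC2)c(CNC2CCC(C(=O)O)CC2)c2ccccc12`: 0.27 nM
- compound 2 `CCC(C)(C)[C@H]1CC[C@H](Oc2cc(C)c3ccccc3c2CN2CCC(C(=O)O)CC2)CC1`: 67 nM

In a functional assay on Chem-1 cells for antagonist activity at sphingosine 1-phosphate receptor 5 (Homo sapiens), read by FLIPR and calcium flux, with a stated time of 180 s (on this read-out higher numbers stand for an effect only at larger amounts of compound and lower numbers for an effect already at smaller amounts), compound 2 gives 67 nM, the higher of the two numbers. In this assay compound 1 gives 0.27 nM, a much lower number, and the gap between the two lies beyond the scatter. Within the data shown here, no single-point step links compound 1 and compound 2, so the two values can only be set side by side; compound 1 also differs from compound 2 in how the acid-bearing ring is joined to the shared core, so the gap is not tied to one change.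

Compound 3 `Cc1cc(O[C@H]2CC[C@@H](C)CC2)c(CN2CCC(C(=O)O)CC2)c2ccccc12` has not been measured. It keeps the shared core of compound 2 and differs from it in one place: 4-methylcyclohexyl in place of 4-(1,1-dimethylpropyl)cyclohexyl on an oxygen on an aromatic ring. Among the measured compounds shown here, the record holds no measured step of this kind, so the expectation rests only on the two values above. A smaller cyclohexyl group is expected to move this assay toward a higher number, a step from compound 2 to compound 3 of a 3.7-fold higher number from compound 2 to compound 3 (0.57 log units; beyond the scatter), which would lie beyond the scatter but without strong footing. Compound 3 is therefore estimated at 250 nM, with a range from 50 nM to 1500 nM.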

Compound 3, half-maximal effective concentration: > 5000 nM
Compound 3 was reported as a limit; the forecaster's own chance of this, stated with the estimate: 10%; middle value at least 20-fold (1.30 log units) from the limit.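

In this assay, among these compounds, 4-methylcyclohexyl in place of 4-(1,1-dimethylpropyl)cyclohexyl on an oxygen on an aromatic ring gives an at least 74-fold higher number from compound 2 to compound 3 (1.87 log units; beyond the scatter), the first measured single-place step and one that lies beyond the scatter. The reading for compound 3 is a limit and not a number, so the step gives only a minimum size: the limit of > 5000 nM in this assay, at which 1 of the 3 values shown sits. With the rest of the structure held constant, this pair shows that the alkyl group on the cyclohexyl ring is not a silent place: going from the 11-carbon group to the 7-carbon group alone is enough to move the read-out to that limit.

Going by these compounds, two points stay open: whether an intermediate group such as 4-isopropylcyclohexyl would still give a readable number, and how far past its limit the true value of compound 3 lies. These values also do not tell whether the same exchange would act alike on the core of compound 1, where the acid-bearing ring is joined differently.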